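Working notes: amino to nitro on the aryl ketone ring

The source may report more compounds than this note shows. Statements on the series, on what has been measured and on what is new or still open speak of the compounds shown alone.

Measured so far:
compound 1, `CSc1ccc(C(=O)/C=C/c2ccc3c(c2)B(O)OC3)cc1`: 9800 nM
compound 2, `O=C(/C=C/c1ccc2c(c1)B(O)OC2)c1ccc(OCc2ccccc2)cc1`: 5300 nM
compound 3, `Nc1ccc(C(=O)/C=C/c2ccc3c(c2)B(O)OC3)cc1`: 25800 nM

In a functional assay on MDA-MB-231 cells (Homo sapiens) for cytotoxicity, read by MTT assay, with a stated time of 48 h (on this read-out lower numbers stand for stronger inhibition and higher numbers for weaker inhibition), compound 3 holds the highest of the three numbers; the step of a 2.6-fold higher number from compound 1 to compound 3 (0.42 log units; beyond the scatter) and the step of a 4.9-fold higher number from compound 2 to compound 3 (0.69 log units; beyond the scatter) both lie beyond the scatter. Compound 4, `O=C(/C=C/c1ccc2c(c1)B(O)OC2)c1ccc([N+](=O)[O-])cc1`, differs from compound 3 by nitro in place of amino on an aromatic carbon. Among the compounds with values here, no measured step exchanges amino for nitro, so the change is not directly covered. Within the data shown here, the steps that bear on it are those in which amino replaced another group on the same aromatic carbon, a 2.6-fold higher number from compound 1 to compound 3 (0.42 log units; beyond the scatter) and a 4.9-fold higher number from compound 2 to compound 3 (0.69 log units; beyond the scatter), both modest and both toward higher numbers. Removing amino in favour of another group is therefore expected to move this assay back toward lower numbers by a modest step, a 2.6-fold lower number from compound 3 to compound 4 (0.41 log units; beyond the scatter). Compound 4 is estimated at 10000 nM, within a range from 3500 nM to 30000 nM.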

Compound 4, half-maximal inhibitory concentration: 11200 nM
Compound 4: middle estimate off by 1.1-fold (0.05 log units), on the low side; measured number inside the range.
By their numbers in this assay, from the lowest: compounds 2, 1 and 4 (each within the scatter of the next, the first and the last beyond it); then compound 3.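

In this assay nitro in place of amino on this aromatic carbon gives a modest step toward stronger inhibition (a 2.3-fold lower number from compound 3 to compound 4 (0.36 log units; beyond the scatter)). This shows that a group with no hydrogen-bond donor can stand here without the higher number of compound 3, and nitro is not separated from methylsulfanyl (a 1.1-fold higher number from compound 1 to compound 4 (0.06 log units; within the scatter)). Benzyloxy still keeps a modest edge over nitro (a 2.1-fold higher number from compound 2 to compound 4 (0.32 log units; beyond the scatter)). Nothing shown gives a cause for these steps. From the compounds shown here alone, how a carboxylic acid or a longer alkoxy chain on this carbon would compare remains open.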